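The compounds below may be only part of what the source reports. "The series", "measured", "known", "first", "only" and "open" are said of these compounds alone.

Working notes on the series, read in a functional assay on HepG2 cells (Homo sapiens) for antiproliferative activity, read by MTT assay, with a stated time of 24 h; on this read-out lower numbers stand for stronger inhibition and higher numbers for weaker inhibition. Compound 1 `Cc1ccc(-c2nn(-c3ccccc3)cc2-c2nc3ccccc3n2S(=O)(=O)c2ccccc2)cc1` gives 960 nM, compound 2 `Cc1ccc(-c2nn(-c3ccccc3)cc2-c2nc3ccccc3n2S(=O)(=O)c2ccc(F)cc2)cc1` gives 5060 nM, and compound 3 `Cc1ccc(-c2nn(-c3ccccc3)cc2-c2nc3ccccc3n2S(=O)(=O)c2ccc(Cl)cc2)cc1` gives 5520 nM. Compound 3 thus lies within the scatter of compound 2, and both are weaker than compound 1. Compound 4 `Cc1ccc(-c2nn(-c3ccccc3)cc2-c2nc3ccccc3n2S(=O)(=O)c2ccc(C(F)(F)F)cc2)cc1` follows from compound 3 by one change: trifluoromethyl in place of chloro on an aromatic carbon. Two modest steps mark the loss on adding a halogen in place of hydrogen: a 5.3-fold higher number from compound 1 to compound 2 (0.72 log units; beyond the scatter) and a 5.8-fold higher number from compound 1 to compound 3 (0.76 log units; beyond the scatter). Exchanging one halogen for the other gives a 1.1-fold higher number from compound 2 to compound 3 (0.04 log units; within the scatter), which stays within the scatter. Within the data shown here, no measured step involves trifluoromethyl, so the closest guide is this last exchange, and no shift beyond the scatter is expected. The expected step is a 1.1-fold higher number from compound 3 to compound 4 (0.04 log units; within the scatter). Compound 4 is estimated at 6000 nM, with an expected range of 2500 nM to 14000 nM.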

Compound 4, half-maximal inhibitory concentration: 1930 nM
For compound 4 the middle estimate is 3.1-fold (0.49 log units) above the measured one, outside the stated range (below it).
By their numbers in this assay, from the lowest: compounds 1 and 4 (each within the scatter of the next); then compounds 2 and 3 (each within the scatter of the next).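

Trifluoromethyl here parts from the two halogens: the exchange for chloro gives a 2.9-fold lower number from compound 3 to compound 4 (0.46 log units; beyond the scatter) and the exchange for fluoro gives a 2.6-fold lower number from compound 2 to compound 4 (0.42 log units; beyond the scatter) on this same aromatic carbon. Hydrogen to trifluoromethyl gives a 2.0-fold higher number from compound 1 to compound 4 (0.30 log units; within the scatter) and so, unlike fluoro and chloro, this substituent shows no loss beyond the scatter, which means a halogen exchange alone is a poor guide at this position. Nothing at hand gives a reason for this split among the substituents.

Open, on these data alone, is how a methoxy, a nitrile or an amine at this place would compare with trifluoromethyl and hydrogen. Also open, as far as these compounds go, is whether the split holds with other groups on the shared core.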